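This account rests on a few compounds, and the source may have more. Where it says the series, first, only, none or still open, it means among the compounds named here.

Values in a functional assay for agonist activity at G protein-coupled receptor 88 (Homo sapiens), read by HTRF and cAMP accumulation; a lower number here means that less compound is needed, a higher number that more compound is needed for the effect:

compound 1 `CC(C)[C@H](N)CN(C(=O)[C@@H]1C[C@H]1c1ccccc1)c1ccc(-c2ccccc2)cc1`: 1.1 nM
compound 2 `CC(C)(N)CN(C(=O)[C@@H]1C[C@H]1c1ccccc1)c1ccc(-c2ccccc2)cc1`: 1.4 nM
compound 3 `CC[C@H](C)[C@H](N)CN(C(=O)[C@@H]1C[C@H]1c1cccc(Cl)c1)c1ccc(-c2ccccc2)cc1`: 2200 nM

Compound 3 gives the highest number of the three, and its gap to compound 2 as well as to compound 1 lies beyond the scatter; compound 1 and compound 2 sit together, the step between them, a 1.3-fold higher number from compound 1 to compound 2 (0.10 log units; within the scatter), being within the scatter.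

Compound 4 `CC[C@H](C)[C@H](N)CN(C(=O)[C@@H]1C[C@H]1c1cccc(C#N)c1)c1ccc(-c2ccccc2)cc1` is the next compound, not yet measured. It differs from compound 3 in one place: cyano in place of chloro on an aromatic carbon. For the measured compounds named here, the only measured step, a 1.3-fold higher number from compound 1 to compound 2 (0.10 log units; within the scatter), concerns the group on the saturated chain carbon bound to the amide-type nitrogen and leaves the aromatic ring untouched; no measured pair shares the exchange on the 3-chlorophenyl ring, so nothing in the data sets a size or a direction for this step. The working expectation is therefore a number close to that of compound 3, with no step beyond the scatter predicted and a wide range to allow for the lack of any matched pair.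

For compound 4 the estimated step is a 1.1-fold lower number from compound 3 to compound 4 (0.04 log units; within the scatter). The expected value for compound 4 in this assay is 2000 nM, with a range of 400 nM to 10000 nM.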

Compound 4, half-maximal effective concentration: 1600 nM
Estimate against measurement, compound 4: 1.3-fold (0.10 log units) above; measured number inside the range.
By their numbers in this assay, from the lowest: compounds 1 and 2 (each within the scatter of the next); then compounds 4 and 3 (each within the scatter of the next).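

Working notes: in this assay, cyano in place of chloro on an aromatic carbon meta to a large group gives a 1.4-fold lower number from compound 3 to compound 4 (0.14 log units; within the scatter) and so provides the first matched pair at this place on the ring. Cyano brings a triple bond, a hydrogen-bond acceptor and one more heavy atom, yet in this single pair the assay does not tell it apart from chloro, so this place accepts the exchange without a step beyond the scatter, here at the high end of the numbers shown. No measurement on hand accounts for this outcome.

Compounds 3 and 4 each differ from compound 1 in more than one place, so the shares of the ring substituent and of the chain group in their numbers cannot be read from the compounds shown. Also open, on these data alone, is whether other groups at this place, such as methoxy, trifluoromethyl, a carboxylic acid or an amine, would stay with compound 3 and compound 4, and whether the same exchange would read alike with the chain group of compound 1.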